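The source may report more compounds than this note shows. Statements on the series, on what has been measured and on what is new or still open speak of the compounds shown alone.

Four compounds share one core and differ at two places on it. Compound 1 `COC(=O)C[C@H](NC(=O)OC(C)(C)C)C(=O)N(Cc1ccccc1)C1(C(=O)NCc2ccccc2)CCN(Cc2ccccc2)CC1` carries a benzyl on an amide-type nitrogen and a tert-butyl on an oxygen next to a carbonyl group. In a functional assay on L1210 cells (Mus musculus) for inhibition, with a stated time of 48 h (on this read-out higher numbers stand for weaker inhibition and lower numbers for stronger inhibition), compound 1 gives 18000 nM. Compound 2 `CCC(C)N(C(=O)[C@H](CC(=O)OC)NC(=O)OC(C)(C)C)C1(C(=O)NCc2ccccc2)CCN(Cc2ccccc2)CC1` differs from compound 1 in one place: sec-butyl in place of benzyl on an amide-type nitrogen. In this assay compound 2 gives 20000 nM, so a 1.1-fold higher number from compound 1 to compound 2 (0.05 log units; within the scatter). Compound 3 `COC(=O)C[C@H](NC(=O)OCc1ccccc1)C(=O)N(Cc1ccccc1)C1(C(=O)NCc2ccccc2)CCN(Cc2ccccc2)CC1` differs from compound 1 at the other place: benzyl in place of tert-butyl on an oxygen next to a carbonyl group. In this assay compound 3 gives 5800 nM, and a 3.1-fold lower number from compound 1 to compound 3 (0.49 log units; beyond the scatter).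

Compound 4 `CCC(C)N(C(=O)[C@H](CC(=O)OC)NC(=O)OCc1ccccc1)C1(C(=O)NCc2ccccc2)CCN(Cc2ccccc2)CC1` has not been measured. It stands to compound 3 as compound 2 stands to compound 1: sec-butyl in place of benzyl on an amide-type nitrogen. The surroundings of this change are described in the same words for both pairs, so it is the same change, and it appears in two pairs among these compounds. Among the compounds with values here, the only measured example of it, from compound 1 to compound 2, stayed within the scatter, so a similar outcome is the natural expectation for compound 4, with compound 3 as its starting point. The expected step is a 1.1-fold higher number from compound 3 to compound 4 (0.05 log units; within the scatter). Compound 4 is estimated at 6500 nM in this assay, with the likely range running from 3000 nM to 14000 nM.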

Compound 4, half-maximal inhibitory concentration: 5300 nM
The estimate for compound 4 lay 1.2-fold (0.09 log units) above the measured number, within the range that was stated.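

In this assay, putting sec-butyl in place of benzyl on the amide-type nitrogen again left the number within the scatter, with a 1.1-fold lower number from compound 3 to compound 4 (0.04 log units; within the scatter), so this swap behaved alike whichever group sat on the oxygen next to the carbonyl group: the same change on two cores in this assay, a 1.1-fold higher number (0.05 log units; within the scatter) from compound 1 to compound 2 and a 1.1-fold lower number (0.04 log units; within the scatter) from compound 3 to compound 4, 1.2-fold (0.08 log units) apart, within the scatter of two such steps

The other change, benzyl in place of tert-butyl on that oxygen, also carried over from one core to the other, with a 3.8-fold lower number from compound 2 to compound 4 (0.58 log units; beyond the scatter): the same change on two cores in this assay, a 3.1-fold lower number (0.49 log units; beyond the scatter) from compound 1 to compound 3 and a 3.8-fold lower number (0.58 log units; beyond the scatter) from compound 2 to compound 4, 1.2-fold (0.08 log units) apart, within the scatter of two such steps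

Among these four compounds, then, each change gave a similar step whatever stood at the other place, but each comparison rests on just two pairs in one assay, so this does not show that the same would hold for other groups or other cores, and it does not say why the steps match.

The two groups shown on the amide-type nitrogen contain carbon only, so it remains open what an amine or a carboxylic acid carried on a chain at that nitrogen would do. On the oxygen only tert-butyl and benzyl appear, which leaves open whether a longer chain or a benzyl ring bearing a fluorine would extend the step seen there.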